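Thioether side chains on the shared dinitrile core

The source may report more compounds than this note shows. Statements on the series, on what has been measured and on what is new or still open speak of the compounds shown alone.

Compound 1 `N#Cc1ccc(SCc2ccccc2)cc1C#N`, compound 2 `N#Cc1ccc(Sc2ccc(Br)cc2)cc1C#N` and compound 3 `N#Cc1ccc(SCCc2ccccc2)cc1C#N` share one core and differ only in the group attached to the sulfur. In an assay on microsomes for inhibition of Amine oxidase [flavin-containing] B (Homo sapiens), read by fluorescence and spectrophotometry, with a stated time of 20 min (on this read-out lower numbers stand for stronger inhibition and higher numbers for weaker inhibition), compound 1 gives 167 nM, compound 2 gives 79 nM and compound 3 gives 124 nM. Compound 3 holds the second highest of the three numbers; compound 1 lies nearest and compound 2 furthest, both within the scatter, so no order among the three can be stated. Compound 4 `CC(C)CCSc1ccc(C#N)c(C#N)c1` differs from compound 3 by isopropyl in place of phenyl on a saturated chain carbon, two bonds along the chain from a sulfur. Going by the values given here, no step of this kind has been measured. A modest rise in number from compound 3 to compound 4 is expected, roughly at the edge of the scatter, giving an expected step of a 2.1-fold higher number from compound 3 to compound 4 (0.32 log units; beyond the scatter). For compound 4 in this assay the estimate is 260 nM, within 100 nM to 700 nM.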

Compound 4, half-maximal inhibitory concentration: 242 nM
Beside the measured number, compound 4's estimate is 1.1-fold (0.03 log units) above it; the range from low to high includes it.
By their numbers in this assay, from the lowest: compounds 2, 3, 1 and 4 (each within the scatter of the next, the first and the last beyond it).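

With isopropyl in place of phenyl on a saturated chain carbon, two bonds along the chain from a sulfur, the series gives a 2.0-fold higher number from compound 3 to compound 4 (0.29 log units; within the scatter) and with isobutyl in place of phenyl on a saturated chain carbon bound to a sulfur it gives a 1.4-fold higher number from compound 1 to compound 4 (0.16 log units; within the scatter). Both steps lie within the scatter, so compounds 1, 3 and 4 do not show that a six-membered aromatic ring of carbon is needed on this chain. No evidence on the cause of these results is available.

Still open, as far as these compounds go, is how an amine or a carboxylic acid would read at this chain position. From the compounds shown here alone, a longer chain also remains open.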